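Methyl on the oxygen of compound 3

This account rests on a few compounds, and the source may have more. Where it says the series, first, only, none or still open, it means among the compounds named here.

Compound 1 `Nc1ccc(S(=O)(=O)N2CCN(c3ncc(C(O)(C(F)(F)F)C(F)(F)F)cc3Br)CC2)cn1`: < 14 mL.min-1.g-1 (a limit)
Compound 2 `Nc1ccc(S(=O)(=O)N2CCN(c3ncc(C(O)(C(F)(F)F)C(F)(F)F)cc3C3CC3)CC2)cn1`: 38 mL.min-1.g-1
Compound 3 `Nc1ccc(S(=O)(=O)N2CCN(c3ncc(C(O)(C(F)(F)F)C(F)(F)F)cc3C#CCO)CC2)cn1`: < 14 mL.min-1.g-1 (a limit)

All three compounds were measured in an ADME assay (liver) for metabolic stability, with Liver microsome (Homo sapiens) as the target, using microsomes and NADPH, with a stated time of 30 min, tested at 1 uM; a higher number here means faster removal of the compound, a lower number slower removal. Compound 3 stands at the limit of < 14 mL.min-1.g-1 in this assay, at which 2 of the 3 values shown sit, so its reading is a limit and not a number. Compound 4 `COCC#Cc1cc(C(O)(C(F)(F)F)C(F)(F)F)cnc1N1CCN(S(=O)(=O)c2ccc(N)nc2)CC1` differs from it by one change, methyl in place of hydrogen on an oxygen on a saturated carbon: methyl in place of hydrogen on an oxygen, which turns 3-hydroxyprop-1-yn-1-yl into 3-methoxyprop-1-yn-1-yl.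

Among the compounds with values here, no measured step makes this exact change. The nearest evidence comes from replacing the whole group at that place, which gave an at least 2.7-fold higher number from compound 1 to compound 2 (0.43 log units; beyond the scatter) and an at least 2.7-fold lower number from compound 2 to compound 3 (0.43 log units; beyond the scatter). The remaining pair gives a step that the two limits leave unreadable from compound 1 to compound 3. These steps show that the read-out in this assay can respond to the group at this place, but they swap larger groups than a single methyl. A small rise is therefore expected, and the expected step is an at least 1.2-fold higher number from compound 3 to compound 4 (0.10 log units; that floor lies within the scatter). For compound 4 the estimated value is 18 mL.min-1.g-1, with an expected range of 9 mL.min-1.g-1 to 40 mL.min-1.g-1.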

Compound 4, intrinsic clearance in microsomes: 15 mL.min-1.g-1
The estimate for compound 4 lay 1.2-fold (0.08 log units) above the measured number; the range from low to high includes it.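

In this assay, within the data shown here, turning 3-hydroxyprop-1-yn-1-yl into 3-methoxyprop-1-yn-1-yl gave an at least 1.0-fold higher number from compound 3 to compound 4 (0.02 log units; that floor lies within the scatter), so methyl on this oxygen produced no step that can be told from the scatter. The readings of compound 1 and compound 3 are both limits, so the true size of any step from them stays hidden: the limit of < 14 mL.min-1.g-1 in this assay, at which 2 of the 4 values shown sit. The methoxy group still gave a 2.5-fold lower number from compound 2 to compound 4 (0.40 log units; beyond the scatter), which keeps the separation from cyclopropyl beyond the scatter, while the comparison with bromo gave only an at least 1.0-fold higher number from compound 1 to compound 4 (0.02 log units; that floor lies within the scatter).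

The compounds shown leave open how large the step from the hydroxy group really is. They also leave open whether a longer chain on this oxygen, such as ethoxy, or an amine in place of the hydroxy, would give a number close to that of compound 4.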